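The source may report more compounds than this note shows. Statements on the series, on what has been measured and on what is new or still open speak of the compounds shown alone.

Measured so far in a functional assay on HCT-116 cells (Homo sapiens) for cytotoxicity, read by sulforhodamine B assay, with a stated time of 72 h; on this read-out higher numbers stand for weaker inhibition and lower numbers for stronger inhibition:
compound 1 `CCS(=O)(=O)Nc1cc(-c2ccc3ncnc(Nc4cccc(C(=O)OC)c4)c3c2)cnc1OC`: 400 nM
compound 2 `CCS(=O)(=O)Nc1cc(-c2ccc3ncnc(Nc4ccc(Cl)c(C(=O)OC)c4)c3c2)cnc1OC`: 3130 nM

Compound 1 gives the lowest of the two numbers; its nearest neighbour is compound 2, reached by a 7.8-fold higher number from compound 1 to compound 2 (0.89 log units; beyond the scatter), a change that concerns a chloro in place of hydrogen on an aromatic carbon, not the sulfonyl group. Compound 3 `COC(=O)c1cccc(Nc2ncnc3ccc(-c4cnc(OC)c(NS(=O)(=O)c5ccc(F)cc5F)c4)cc23)c1` differs from compound 1 by 2,4-difluorophenyl in place of ethyl on a sulfonyl sulfur; the sulfonamide nitrogen and the rest of the shared core are unchanged. Among the compounds with values here, the one measured step therefore does not bear on this change, and no measured pair shows what exchanging the group on the sulfonyl sulfur does in this assay. With no guide from the data, the number for compound 3 is expected to stay close to that of compound 1, the estimated step being a 1.5-fold higher number from compound 1 to compound 3 (0.18 log units; within the scatter), with a wide range to either side. Compound 3 is estimated at 600 nM, range 150 nM to 4000 nM.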

Compound 3, half-maximal inhibitory concentration: 1500 nM
Compound 3: middle estimate off by 2.5-fold (0.40 log units), on the low side; the range from low to high includes it.
By their numbers in this assay, from the lowest: compound 1; then compound 3; then compound 2.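

In this assay, within the data shown here, the group on the sulfonyl sulfur proves open to exchange but not without effect: 2,4-difluorophenyl in place of ethyl gives a 3.8-fold higher number from compound 1 to compound 3 (0.57 log units; beyond the scatter) and is the first measured step at this position. The exchange weakens inhibition without removing it, since compound 3 still gives 1500 nM and so carries an aromatic ring on the sulfonyl sulfur with activity retained. Among these compounds, nothing measured so far accounts for this step.

Still open, as far as these compounds go, is whether the step belongs to the aromatic ring itself or to its two fluorines, which a plain phenyl on the sulfonyl sulfur would separate. Also open, from the compounds shown here alone, is how a methyl, a propyl chain or a chain ending in an amine would read at this place in this assay and whether the chloro step seen with ethyl carries over to the 2,4-difluorophenyl group.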